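The compounds below may be only part of what the source reports. "The series", "measured", "known", "first", "only" and "open" are said of these compounds alone.

Measured so far:
Compound 1 `CNC(=O)c1ccc(=O)n(Cc2cc(Br)ccc2F)c1` — in a physicochemical assay for solubility (on this read-out lower numbers stand for lower solubility and higher numbers for higher solubility), compound 1 reaches a limit of the assay rather than a number: >= 143 ug/mL.
Compound 2 `CNC(=O)c1cc(C(=O)NC2CC2)cn(Cc2ccc(C)cc2)c1=O` — in this assay compound 2 gives 24 ug/mL.
Compound 3 `CNC(=O)c1cc(C(=O)NCC(C)C)cn(Cc2ccccc2)c1=O` — in this assay compound 3 gives 43 ug/mL.

Compound 2 carries the smaller of the two numbers, but compound 3 lies within the scatter of it, so the two are not told apart. The value of compound 1 is a limit of >= 143 ug/mL in this assay, at which 1 of the 3 values shown sits, and is left aside. Among the compounds with values here, no pair of measured compounds differs in a single place, so nothing in this set measures the change now considered. Compound 4 `CNC(=O)c1cc(C(=O)NC2CC2)cn(Cc2cccc3c2CCN3)c1=O` differs from compound 2 as follows: 2,3-dihydro-1H-indol-4-yl in place of 4-methylphenyl on a saturated chain carbon bound to an aromatic nitrogen. In this assay a small rise, at the edge of the scatter, is expected, as a 2.1-fold higher number from compound 2 to compound 4 (0.32 log units; beyond the scatter). Compound 4 is estimated at 50 ug/mL in this assay, between 15 ug/mL and 160 ug/mL.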

Compound 4, solubility: >= 184 ug/mL
Compound 4 was reported as a limit (the forecaster's own chance of this, stated with the estimate: 10%); at least 3.6-fold (0.56 log units) between middle value and limit.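

Putting 2,3-dihydro-1H-indol-4-yl in place of 4-methylphenyl on a saturated chain carbon bound to an aromatic nitrogen gives, in this assay, an at least 7.6-fold higher number from compound 2 to compound 4 (0.88 log units; beyond the scatter). Within the data shown here, this is the first single-place step, and it shows that the group at this position can move the read-out beyond the scatter. Compound 4 gives a limit, not a number, so the step has a lower bound only: the limit of >= 184 ug/mL in this assay, at which 1 of the 4 values shown sits.

The step does not separate the effect of the added nitrogen from that of the five-membered non-aromatic ring. As far as these compounds go, an aminophenyl group at this position would keep the nitrogen without that ring, and its step remains open.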